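Acetylated sugar enones: aryl change from compound 3 to 4

The source may hold more compounds than are shown below. What is called first, only, known or untested is meant among the compounds shown, and "the series" means these compounds.

In an ADME assay on cells (Epithelial cell, Homo sapiens) for cytotoxicity, read by MTT assay, with a stated time of 24 h (a higher number here means that more compound is tolerated, a lower number that less compound is tolerated), compound 1 `CC(=O)OC[C@H]1O[C@@H](CC(=O)/C=C/c2cccs2)[C@H](OC(C)=O)[C@@H](OC(C)=O)[C@@H]1OC(C)=O` carries "not determined" (no result reported), and compound 2 `COc1cc(/C=C/C(=O)C[C@@H]2O[C@H](COC(C)=O)[C@@H](OC(C)=O)[C@H](OC(C)=O)[C@H]2OC(C)=O)ccc1O` carries "not determined" (no result reported). Within the data shown here, compound 3 `CC(=O)OC[C@H]1O[C@@H](CC(=O)/C=C/c2cccc([N+](=O)[O-])c2)[C@H](OC(C)=O)[C@@H](OC(C)=O)[C@@H]1OC(C)=O` is the only member with a number: in this assay compound 3 gives 15.5 nM, so it stands alone and no comparison is possible. Compound 4 `CC(=O)OC[C@H]1O[C@@H](CC(=O)/C=C/c2ccc(C)cc2)[C@H](OC(C)=O)[C@@H](OC(C)=O)[C@@H]1OC(C)=O` differs from compound 3 in one place: 4-methylphenyl in place of 3-nitrophenyl on a double-bonded chain carbon bound to a double-bonded chain carbon. Among the measured compounds shown here, no measured pair shows what such a swap does in this assay, so the size and direction of the step remain open. The expectation is a step from compound 3 to compound 4 of a 1.3-fold higher number from compound 3 to compound 4 (0.11 log units; within the scatter), which is not expected to exceed the scatter. Compound 4 is estimated at 20 nM, with a range from 6 nM to 70 nM.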

Compound 4, half-maximal cytotoxic concentration: 3.18 nM
Compound 4: middle estimate off by 6.3-fold (0.80 log units), on the high side; the whole stated range lies above it.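

In this assay, among these compounds, the aryl group on a double-bonded chain carbon bound to a double-bonded chain carbon now has its first readable step: 4-methylphenyl in place of 3-nitrophenyl gives a 4.9-fold lower number from compound 3 to compound 4 (0.69 log units; beyond the scatter) in the only pair with two numbers. Less of compound 4 is tolerated, so the number at this position responds to the aryl group. Nothing measured here accounts for the step.

One pair cannot separate the loss of nitro from the gain of methyl. From the compounds shown here alone, how an amine or a carboxylic acid on the phenyl ring would read remains open.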